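The source may report more compounds than this note shows. Statements on the series, on what has been measured and on what is new or still open speak of the compounds shown alone.

Series read in an ADME assay on THP-1 cells (Homo sapiens) for cytotoxicity, read by flow cytometry, with a stated time of 72 h; a higher number here means a weaker inhibitor, a lower number a stronger inhibitor:

compound 1 `N/C(=N\O)c1ccc(C2=C(S(=O)(=O)c3ccccc3)CC(c3ccccc3)(c3ccccc3)O2)cc1` gives 30600 nM
compound 2 `N/C(=N\O)c1ccc(C2=C(S(=O)(=O)c3ccc(/C(N)=N/O)cc3)CC(c3ccccc3)(c3ccccc3)O2)cc1` gives 119000 nM

Among the measured compounds shown here, compound 2 stands highest of the two numbers measured in this assay; its nearest neighbour is compound 1, and the single step recorded, a 3.9-fold higher number from compound 1 to compound 2 (0.59 log units; beyond the scatter), lies beyond the scatter. That step is the only measured one and it bears on compound 3 only indirectly: it shows that attaching a polar group of four heavy atoms to the aromatic carbon of the sulfonyl-bearing ring pushed the number up.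

Compound 3 `N/C(=N\O)c1ccc(Nc2ccc(S(=O)(=O)C3=C(c4ccc(/C(N)=N/O)cc4)OC(c4ccccc4)(c4ccccc4)C3)cc2)cc1` differs from compound 2 in the same place. The change is a group of 11 heavy atoms (7 carbon, 3 nitrogen, 1 oxygen; one six-membered aromatic ring of carbon only) in place of a group of 4 heavy atoms (1 carbon, 2 nitrogen, 1 oxygen; no ring), on an aromatic carbon. The group that enters is larger than the one that leaves and is placed on an aromatic carbon of a six-membered aromatic ring of carbon only, para to a large group.

With one step in hand, no firm direction can be read off. The expectation is a step in this assay of about a 1.3-fold higher number from compound 2 to compound 3 (0.10 log units; within the scatter), small against the scatter, with the number for compound 3 estimated at 150000 nM, within a range of 50000 nM to 400000 nM.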

Compound 3, half-maximal inhibitory concentration: > 50000 nM
Compound 3 gave a limit, no number; the forecaster's own chance of this, stated with the estimate: 35%; the middle value lies beyond the limit too.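

In this assay compound 3 gives only a limit of the assay, not a number: the limit of > 50000 nM in this assay, at which 1 of the 3 values shown sits.

Set against the hydrogen atom on this aromatic carbon, the group of 11 heavy atoms gives an at least 1.6-fold higher number from compound 1 to compound 3 (0.21 log units; that floor lies within the scatter), so the position tolerates this much larger group without the number falling under that floor, though the true size of the step stays hidden behind the limit. The step from the group of 4 heavy atoms to the group of 11 heavy atoms cannot be read, so the series does not say whether adding the six-membered aromatic ring of carbon only moves the number further, leaves it in place or brings it back.

Still open, from the compounds shown here alone, is how a small group on this aromatic carbon, such as an amine or a carboxylic acid, would read in this assay, where a measured number rather than a limit could place it against compound 1 at 30600 nM and compound 2 at 119000 nM. Also open, going by these compounds, is whether any group at this place gives a number lower than that of the hydrogen atom in compound 1.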